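The source may report more compounds than this note shows. Statements on the series, on what has been measured and on what is new or still open speak of the compounds shown alone.

In an ADME assay on HEp-2 cells (Homo sapiens) for cytotoxicity (a higher number here means that more compound is tolerated, a lower number that less compound is tolerated), compound 2 `CC(C)CCn1c(CN2C(=O)C(O)c3ccccc32)nc2ccccc21` gives 3310 nM. Compound 3 `CC(C)CCn1c(CN2C(=O)C(CC(=O)N(C)C)c3ccccc32)nc2ccccc21` gives 4670 nM, and the measured change is a 1.4-fold higher number from compound 2 to compound 3 (0.15 log units; within the scatter). Compound 1 `CC(C)CCn1c(CN2C(=O)C(CC(=O)NCc3ccccc3)c3ccccc32)nc2ccccc21` gives 720 nM, and the step away from it is a 4.6-fold higher number from compound 1 to compound 2 (0.66 log units; beyond the scatter). Compound 4 `CC(C)CCn1c(CN2C(=O)C(C)(O)c3ccccc32)nc2ccccc21` differs from compound 2 by methyl in place of hydrogen on a saturated ring carbon. Among the compounds with values here, no measured step makes this exact change. The nearest guides are two swaps at a saturated ring carbon, which are far larger than this one. One of them, a 1.4-fold higher number from compound 2 to compound 3 (0.15 log units; within the scatter), stayed close, while the other, a 4.6-fold higher number from compound 1 to compound 2 (0.66 log units; beyond the scatter), was modest. An estimated step of a 1.1-fold lower number from compound 2 to compound 4 (0.04 log units; within the scatter) is therefore expected, with nothing beyond the scatter anticipated. The expected value for compound 4 is 3000 nM, within an estimated range of 1400 nM to 6500 nM.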

Compound 4, half-maximal cytotoxic concentration: 101000 nM
Estimate against measurement, compound 4: 34-fold (1.53 log units) below; the whole stated range lies below it.
By their numbers in this assay, from the lowest: compound 1; then compounds 2 and 3 (each within the scatter of the next); then compound 4.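

In this assay, methyl in place of hydrogen on a saturated ring carbon already bearing hydroxy gives a 31-fold higher number from compound 2 to compound 4 (1.48 log units; beyond the scatter). The earlier swaps on this ring carbon involved far larger groups, yet this single added carbon produced the largest step, so the size of the change did not track the size of the effect in these compounds. Nothing in the data at hand accounts for this step. The compounds shown leave open whether an ethyl group or a longer chain here would give a similar step, and whether methyl would do so with a methoxy group in place of the hydroxy.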